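The source may report more compounds than this note shows. Statements on the series, on what has been measured and on what is new or still open speak of the compounds shown alone.

Measured compounds:
compound 1, `C=CCn1c(SCC(=O)Nc2ccc(/C(C)=N/O)cc2)nnc1-c1ccccc1`, 71%
compound 2, `C/C(=N\O)c1ccc(NC(=O)CSc2nnc(-c3ccccc3)n2-c2ccccc2)cc1`, 66%
compound 3, `C=CCn1c(SCC(=O)Nc2ccc(C(C)=O)cc2)nnc1-c1ccc(OC)cc1`, 66%

Of the compounds shown here, three have been tested in a functional assay on the whole organism (strain albino) for inhibition, with Rattus norvegicus as the target, read by paw edema, with stated times of 30 min and 5 h, at a dose of 0.28 mmol/kg by the oral route; a lower number here means less inhibition, a higher number more inhibition at the dose given (going by the name of the read-out). Compound 1 gives 71%. Compound 2 differs from it by phenyl in place of allyl on an aromatic nitrogen, and this single change gave a number 5 percentage points lower from compound 1 to compound 2 (within the scatter). Compound 3 rests on another core; the difference between its core and that of compound 1 is not broken down here. In this assay compound 3 gives 66%, which is level with compound 2 at the digits reported and within the scatter of compound 1.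

Compound 4, `COc1ccc(-c2nnc(SCC(=O)Nc3ccc(C(C)=O)cc3)n2-c2ccccc2)cc1`, has not yet been measured. It differs from compound 3 by phenyl in place of allyl on an aromatic nitrogen. This is the same kind of change as that from compound 1 to compound 2, though the ring atom next to the place bears a 4-methoxyphenyl group in compound 3 rather than a phenyl group as in compound 1. Because the earlier step was a number 5 percentage points lower from compound 1 to compound 2 (within the scatter), a step of similar size is expected, so for compound 4 the estimate is a number 4 percentage points lower from compound 3 to compound 4 (within the scatter). Compound 4 is therefore expected to give about 62% in this assay, most likely between 50% and 74%.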

Compound 4, a percentage reported as inhibition, in the whole organism at one dose (the size of the read-out at that dose, not a potency): 60%
Compound 4: the middle estimate sits 2 percentage points above what was measured, within the range that was stated.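

In this assay, phenyl in place of allyl on an aromatic nitrogen gave a number 6 percentage points lower from compound 3 to compound 4 (within the scatter). Set beside the earlier step, the change behaves alike on the core of compound 1 and on the core of compound 3, with no difference between the two steps: the same change on two cores in this assay, a number 5 percentage points lower (within the scatter) from compound 1 to compound 2 and a number 6 percentage points lower (within the scatter) from compound 3 to compound 4, 1 percentage points apart, within the scatter of two such steps

Within the data shown here, this shows only that the exchange of allyl for phenyl leaves the read-out within the scatter on both cores. It does not show that phenyl lowers inhibition on either core, and two cores read at a single dose cannot speak for the whole series or for potency.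

The compounds shown leave open what other groups on that aromatic nitrogen would give, such as a benzyl group, a longer chain or a chain ending in an amine. They also leave open whether the step would stay this small on a core that carries a carboxylic acid.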